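Aryl ester variation on a bis-methoxyphenyl oxime core

The source may hold more compounds than are shown below. What is called first, only, known or untested is meant among the compounds shown, and "the series" means these compounds.

Measured compounds in a functional assay, with a stated time of 30 min; on this read-out lower numbers stand for stronger inhibition and higher numbers for weaker inhibition:
compound 1, `COc1ccc(C2CC(=NO)CC(c3ccc(OC)cc3)N2C)cc1`, 380000 nM
compound 2, `COc1ccc(C2CC(=NOC(=O)c3ccc(Cl)cc3)CC(c3ccc(OC)cc3)N2C)cc1`, 135000 nM
compound 3, `COc1ccc(C2CC(=NOC(=O)c3cccc(Cl)c3)CC(c3ccc(OC)cc3)N2C)cc1`, 136000 nM

In this assay compound 3 gives 136000 nM, the second highest of the three numbers. Its nearest neighbour is compound 2 with 135000 nM; the step from one chlorophenyl ester to the other is a 1.0-fold higher number from compound 2 to compound 3 (0.00 log units; within the scatter), so the two esters cannot be told apart. Compound 1, the free oxime, gives 380000 nM, and the steps of a 2.8-fold lower number from compound 1 to compound 2 (0.45 log units; beyond the scatter) and a 2.8-fold lower number from compound 1 to compound 3 (0.45 log units; beyond the scatter) show that attaching either chlorophenylcarbonyl group lowers the number modestly.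

Compound 4, `COc1ccc(C2CC(=NOC(=O)c3ccc([N+](=O)[O-])cc3)CC(c3ccc(OC)cc3)N2C)cc1`, has not yet been measured. It differs from compound 3 by 4-nitrophenyl in place of 3-chlorophenyl on a carbonyl carbon. Among the compounds with values here, no measured step exchanges chlorine for a nitro group; the only step at the aryl ester, a 1.0-fold higher number from compound 2 to compound 3 (0.00 log units; within the scatter), lies within the scatter. The aryl ester therefore appears tolerant of substitution, and the step to compound 4 is expected to be a 1.0-fold lower number from compound 3 to compound 4 (0.02 log units; within the scatter), not beyond the scatter. Compound 4 is estimated at 130000 nM, with a range from 50000 nM to 350000 nM.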

Compound 4, half-maximal inhibitory concentration: 280000 nM
For compound 4 the middle estimate is 2.2-fold (0.33 log units) below the measured one; the measured number falls inside the stated range.
By their numbers in this assay, from the lowest: compounds 2 and 3 (each within the scatter of the next); then compounds 4 and 1 (each within the scatter of the next).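

In this assay the aryl ester proves not to be indifferent to its substituent: the two chlorophenyl esters could not be told apart, but nitro in place of chloro on an aromatic carbon separates compound 4 from them (a 2.1-fold higher number from compound 2 to compound 4 (0.32 log units; beyond the scatter); a 2.1-fold higher number from compound 3 to compound 4 (0.31 log units; beyond the scatter)). The lower number seen with the chlorophenylcarbonyl esters relative to the free oxime is also not shared by every aryl ester, as the (4-nitrophenyl)carbonyl group leaves compound 4 within the scatter of compound 1 (a 1.4-fold lower number from compound 1 to compound 4 (0.13 log units; within the scatter)). Nothing measured here explains the difference between the chloro and nitro compounds.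

On these data alone, it remains open whether a nitro group at the 3-position of the phenyl ring would behave like the 4-nitrophenyl ester. As far as these compounds go, how an amine or methoxy group on that ring, or an unsubstituted benzoyl ester, would compare also remains open.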